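A few compounds are considered here, and "the series" means these few. Any claim that something is new, unique, unknown or untested is made for them only; others in the source may bear on it.

Compound 1 `Nc1ccccc1NC(=O)c1ccc(CNC(=O)c2cc3cccnc3[nH]2)cc1` carries a two-ring aromatic amide on its shared core. In an assay on isolated protein for inhibition of Nicotinamide phosphoribosyltransferase (Homo sapiens), read by fluorescence, with stated times of 5 min and 15 min (on this read-out higher numbers stand for weaker inhibition and lower numbers for stronger inhibition), compound 1 gives > 2000 nM, which is a limit of the assay rather than a number. Compound 2 `Nc1ccccc1NC(=O)c1ccc(CNC(=O)c2cc3cnccc3[nH]2)cc1` differs only in how that two-ring group is arranged. In this assay compound 2 gives > 2000 nM, again only a limit. The step that the two limits leave unreadable from compound 1 to compound 2 therefore cannot be read, and on the numbers shown compound 2 stands at the limit, as the one further value does too (the limit of > 2000 nM in this assay, at which 2 of the 2 values shown sit).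

Compound 3 `Nc1ccccc1NC(=O)c1ccc(CNC(=O)c2ccc3cncn3c2)cc1` is built from the same atoms as compound 2, joined differently: a group of 9 heavy atoms (7 carbon, 2 nitrogen; one five-membered aromatic ring with 2 hetero atoms, one six-membered aromatic ring with 1 hetero atom) in place of a group of 9 heavy atoms (7 carbon, 2 nitrogen; one five-membered aromatic ring with 1 hetero atom, one six-membered aromatic ring with 1 hetero atom), on a carbonyl carbon. Going by the values given here, the only measured step that bears on this change is the unreadable one, so no direction beyond the scatter can be expected. Compound 3 is therefore expected to stay near the limit, estimated at 4000 nM with a range from 1000 nM to 20000 nM, the expected step being a step that the limit leaves unreadable from compound 2 to compound 3.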

Compound 3, half-maximal inhibitory concentration: > 2000 nM
Compound 3: a limit, no number; the forecaster's own chance of this, stated with the estimate: 75%; the middle value does not contradict the limit.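

Going by these compounds alone, compound 3 also gives only a limit in this assay, not a number, so no step among compound 1, compound 2 and compound 3 can be read: the limit of > 2000 nM in this assay, at which 3 of the 3 values shown sit. The compounds shown leave open whether these two-ring groups differ at all in how strongly they inhibit the enzyme.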